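A few compounds are considered here, and "the series" means these few. Any claim that something is new, unique, unknown or untested is made for them only; others in the source may bear on it.

This account follows the change from compound 3 to compound 4 in an ADME assay on Vero cells (Chlorocebus sabaeus) for cytotoxicity, read by MTT assay, with a stated time of 72 h; a lower number here means a stronger inhibitor, a higher number a weaker inhibitor. Compound 1 has the structure `CC(C)CNc1nc(=O)c2cc([N+](=O)[O-])cc([N+](=O)[O-])c2s1`. In this assay compound 1 gives "not determined" (no result reported). Compound 2 has the structure `CCCNc1nc(=O)c2cc(C(F)(F)F)cc([N+](=O)[O-])c2s1`. In this assay compound 2 reaches only the assay limit of > 100000 nM. Compound 3 has the structure `CC(C)CNc1nc(=O)c2cc(C(F)(F)F)cc([N+](=O)[O-])c2s1`. In this assay compound 3 likewise reaches only the limit of > 100000 nM. The step that the two limits leave unreadable from compound 2 to compound 3 is thus not readable in size. Compound 3 therefore stands with no single number of its own, beside one further limit and one entry without a result. Compound 4 has the structure `CC1CCN(c2nc(=O)c3cc(C(F)(F)F)cc([N+](=O)[O-])c3s2)CC1`; it differs from compound 3 by 4-methylpiperidin-1-yl in place of isobutylamino on an aromatic carbon. Among the compounds with values here, no measured step crosses that change, and the one step within this set gives no size. Within the data shown here, the only evidence is the limit of > 100000 nM in this assay, at which 2 of the 3 values shown sit. Compound 4 is therefore expected to remain near that limit, with a step that the limit leaves unreadable from compound 3 to compound 4 that is not expected to go beyond the scatter. The estimate for compound 4 is 150000 nM, with a range from 50000 nM to 500000 nM.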

Compound 4, half-maximal inhibitory concentration: > 100000 nM
Compound 4 ended at the assay's limit; the forecaster's own chance of this, stated with the estimate: 80%; the middle value is on the limit's open side.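

Within the data shown here, compound 2, compound 3 and compound 4 all stop at a limit of the assay in this assay, so no step between them can be read. The compounds shown leave open whether any change on the shared core would give a single number in this assay.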